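Cyclohexyl to Isopropyl on a Weak Bile Acid Receptor Series

This account rests on a few compounds, and the source may have more. Where it says the series, first, only, none or still open, it means among the compounds named here.

Measured compounds:
Compound 1, `Cn1c([C@H](CC2CCCCC2)N2C(=O)CN(c3ccc(Oc4ccccc4)cc3)C2=O)nc2ccc(C(=O)O)cc21`: 24400 nM in an assay on isolated protein for inhibition of Bile acid receptor (Homo sapiens), read by TR-FRET and LanthaScreen; on this read-out lower numbers stand for stronger inhibition and higher numbers for weaker inhibition
Compound 2, `Cc1ccc2nc([C@H](CC3CCCCC3)N3C(=O)CN(c4ccc(Oc5ccccc5)cc4)C3=O)n(C)c2c1`: 126000 nM

Among the compounds with values here, only two compounds have been measured in this assay, and compound 2 stands at the higher of the two numbers. Within the data shown here, the single measured step is a 5.2-fold higher number from compound 1 to compound 2 (0.71 log units; beyond the scatter), which moves compound 2 away from compound 1 by a change at an aromatic carbon of the shared core.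

Compound 3, `Cc1ccc2nc([C@H](CC(C)C)N3C(=O)CN(c4ccc(Oc5ccccc5)cc4)C3=O)n(C)c2c1`, differs from compound 2 in one place: isopropyl in place of cyclohexyl on a saturated chain carbon, two bonds along the chain from an amide-type nitrogen in a ring and an aromatic carbon. Among the measured compounds shown here, no measured step bears on this change. The step from compound 1 to compound 2 touches a different place on the core and carries no information about the cyclohexyl. Compound 2 already gives a very high number, so the estimate for compound 3 rests on that starting point alone, with a wide range to cover the absence of any guiding step. Compound 3 is therefore expected to give about 200000 nM, within a range from 50000 nM to 800000 nM. The expected step is a 1.6-fold higher number from compound 2 to compound 3 (0.20 log units; within the scatter), which may well fall within the scatter.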

Compound 3, half-maximal inhibitory concentration: 65600 nM
Compound 3: middle estimate off by 3.0-fold (0.48 log units), on the high side; the measured number falls inside the stated range.
By their numbers in this assay, from the lowest: compound 1; then compounds 3 and 2 (each within the scatter of the next).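

In this assay, within the data shown here, exchanging cyclohexyl for isopropyl on the saturated chain carbon gives a 1.9-fold lower number from compound 2 to compound 3 (0.28 log units; within the scatter), the first reading at this position, which the earlier step on the aromatic carbon could not supply. At this weak level the two compounds cannot be told apart, so the six-membered carbon ring of compound 2 is not required to keep the number where it stands, and the open-chain isopropyl of compound 3, with fewer heavy atoms, serves equally well within the scatter. Nothing available here accounts for this result, and the two compounds alone cannot say whether the position is truly insensitive or whether any effect is simply hidden at such high numbers.

The compounds shown leave open whether isopropyl would read the same with a carboxylic acid in place of the methyl on the aromatic carbon, the group carried by compound 1. They also leave open whether a phenyl, a longer chain or an amine at this chain position would move the number beyond the scatter, in either direction.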